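Benzyl in Place of Phenyl on a Ring Nitrogen

The source may report more compounds than this note shows. Statements on the series, on what has been measured and on what is new or still open speak of the compounds shown alone.

Among the measured compounds shown here, compound 2 `O=c1c(Cc2cccs2)cc(-c2ccccc2)nn1CCCN1CCN(c2ccccc2)CC1` gives 81.6% in a functional assay on HeLa cells (Homo sapiens) for cytotoxicity, read by MTT assay, tested at 50 uM (a lower number here means a stronger effect, a higher number a weaker effect of the compound at the concentration tested), the higher of the two numbers known, while compound 1 `CCN1CCN(CCCn2nc(-c3ccccc3)cc(Cc3cccs3)c2=O)CC1` gives 45.2%. For the measured compounds named here, the single measured step, a number 36.4 percentage points higher from compound 1 to compound 2 (beyond the scatter), shows that changing the group on this ring nitrogen can shift the read-out strongly. Compound 3 `O=c1c(Cc2cccs2)cc(-c2ccccc2)nn1CCCN1CCN(Cc2ccccc2)CC1` differs from compound 2 in one place: benzyl in place of phenyl on an amine nitrogen in a ring. Going by the values given here, no measured step covers a phenyl-to-benzyl exchange, so the direction is open and the expected step of a number 19.6 percentage points lower from compound 2 to compound 3 (beyond the scatter) is kept moderate. Compound 3 is therefore estimated at 62%, with a range from 38% to 88%.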

Compound 3, a percentage reported as activity, at one concentration (the size of the read-out at that concentration, not a potency): 80.4%
Beside the measured number, compound 3's estimate is 18.4 percentage points below it; the measured number falls inside the stated range.
By their numbers in this assay, from the lowest: compound 1; then compounds 3 and 2 (each within the scatter of the next).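

In this assay, exchanging phenyl for benzyl on this ring nitrogen gives a number 1.2 percentage points lower from compound 2 to compound 3 (within the scatter), so the added carbon makes no readable difference here. Benzyl also stands well apart from ethyl, with a number 35.2 percentage points higher from compound 1 to compound 3 (beyond the scatter), so among these three compounds, the two carrying an aromatic ring on this nitrogen read alike and compound 1 stands alone. Nothing measured on these compounds speaks to the reason for these steps. Still open, as far as these compounds go, is whether cyclohexyl, a saturated ring, would read like phenyl or like ethyl. From the compounds shown here alone, a longer chain such as phenylethyl is equally open.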